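Dropping one trifluoromethyl from a diaryl urea

The compounds below may be only part of what the source reports. "The series", "measured", "known", "first", "only" and "open" are said of these compounds alone.

The measurements come from a functional assay on SK-MEL-28 cells (Homo sapiens) for inhibition, read by sulforhodamine B assay, with a stated time of 48 h, tested at 100 uM; a higher number here means a weaker effect of the compound at the concentration tested, a lower number a stronger effect. The three measured compounds are:

Compound 1, `O=C(Nc1cccc(-n2cc(-c3ccncc3)c(-c3cc(O)cc(Cl)c3)n2)c1)Nc1ccc(Cl)c(C(F)(F)F)c1`: compound 1 gives -89%.
Compound 2, `O=C(Nc1cccc(-n2cc(-c3ccncc3)c(-c3cc(O)cc(Cl)c3)n2)c1)Nc1ccc(Cl)c(Cl)c1`: compound 2 gives -52%.
Compound 3, `COc1cc(Cl)cc(-c2nn(-c3cccc(NC(=O)Nc4cc(C(F)(F)F)cc(C(F)(F)F)c4)c3)cc2-c2ccncc2)c1`: compound 3 gives -58%.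

Compound 3 stands second highest of the three numbers. Its nearest neighbour is compound 2, which lies within the scatter of it; compound 1 lies beyond the scatter, lower than compound 3.

Compound 4 is `COc1cc(Cl)cc(-c2nn(-c3cccc(NC(=O)Nc4cccc(C(F)(F)F)c4)c3)cc2-c2ccncc2)c1`. It differs from compound 3 in one place: hydrogen in place of trifluoromethyl on an aromatic carbon.

Among the compounds with values here, no measured step removes a trifluoromethyl outright, but one step replaces it: a number 37 percentage points higher from compound 1 to compound 2 (beyond the scatter). That step was large and went toward a higher number. Losing a trifluoromethyl in compound 4 is therefore expected to move the number in this assay in the same direction, though the size is uncertain because only the step from compound 1 to compound 2 bears on it and the context there differs.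

For compound 4 the expected step is a number 23 percentage points higher from compound 3 to compound 4 (beyond the scatter). The estimate for compound 4 is -35%, with a range from -70% to 0%.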

Compound 4, a percentage reported as activity, at one concentration (the size of the read-out at that concentration, not a potency): -25%
Compound 4: the middle estimate sits 10 percentage points below what was measured; the range from low to high includes it.
By their numbers in this assay, from the lowest: compound 1; then compounds 3 and 2 (each within the scatter of the next); then compound 4.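

Hydrogen in place of trifluoromethyl on this aromatic carbon gives a number 33 percentage points higher from compound 3 to compound 4 (beyond the scatter) in this assay, showing that the number at this position, meta to a trifluoromethyl group, depends on the group being there. The earlier compounds shown here offered only a chloro replacing a trifluoromethyl, a number 37 percentage points higher from compound 1 to compound 2 (beyond the scatter) and in a different context, whereas here the group leaves with no heavy atom entering, and the step is again large and goes the same way. Nothing in the available data accounts for this step.

As far as these compounds go, whether a methyl, a methoxy group or an amine on this carbon would hold the number near that of compound 3 stays open. So does whether the same loss would move the number as far in the core of compound 1.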